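The source may report more compounds than this note shows. Statements on the series, on what has been measured and on what is new or still open speak of the compounds shown alone.

Measured compounds in a functional assay on NALM-6 cells (Homo sapiens); on this read-out higher numbers stand for weaker inhibition and lower numbers for stronger inhibition:
- compound 1, `CSC[C@H](NC(C)=O)C(=O)CCl`, gives 30300 nM
- compound 2, `CCSC[C@H](NC(C)=O)C(=O)CCl`, gives 52800 nM
- compound 3, `CCCCCCSC[C@H](NC(C)=O)C(=O)CCl`, gives 3300 nM

Compound 3 carries the lowest number of the three in this assay; its step from each of the other two is beyond the scatter, so it is the strongest inhibitor among the measured compounds. Compound 2 and compound 1 sit close together: a 1.7-fold higher number from compound 1 to compound 2 (0.24 log units; within the scatter).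

Compound 4, `CCCCCCCSC[C@H](NC(C)=O)C(=O)CCl`, is the next member. Its difference from compound 3 is methyl in place of hydrogen on a saturated chain carbon, six bonds along the chain from a sulfur; the same change, read one bond further out, is methyl to ethyl, ethyl to propyl, propyl to butyl.

Among the measured compounds shown here, two measured steps bear on it, both going in the direction of a longer chain on the sulfur: a 9.2-fold lower number from compound 1 to compound 3 (0.96 log units; beyond the scatter) and a 16-fold lower number from compound 2 to compound 3 (1.20 log units; beyond the scatter). Each lowers the number, the second one by more. For the measured compounds named here, the step to compound 4 is a single carbon added at the end of an already long chain, much smaller than either of those, and no measured pair shows a one-carbon extension beyond the first: the step from compound 1 to compound 2 lies within the scatter.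

A small further lowering is therefore expected, of size a 1.7-fold lower number from compound 3 to compound 4 (0.22 log units; within the scatter), though a value within the scatter of compound 3 would not be surprising. For compound 4 the estimate in this assay is 2000 nM, with a range from 700 nM to 6000 nM.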

Compound 4, half-maximal inhibitory concentration: 4800 nM
For compound 4 the middle estimate is 2.4-fold (0.38 log units) below the measured one; the range from low to high includes it.
By their numbers in this assay, from the lowest: compounds 3 and 4 (each within the scatter of the next); then compounds 1 and 2 (each within the scatter of the next).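

In this assay, methyl in place of hydrogen six bonds along the chain from a sulfur leaves the number within the scatter, a 1.5-fold higher number from compound 3 to compound 4 (0.16 log units; within the scatter), so this position shows no further lowering from the added carbon. A one-carbon extension now reads alike at both ends of the measured chain lengths, on the short chain and on the long one: the same change on two cores in this assay, a 1.7-fold higher number (0.24 log units; within the scatter) from compound 1 to compound 2 and a 1.5-fold higher number (0.16 log units; within the scatter) from compound 3 to compound 4, 1.2-fold (0.08 log units) apart, within the scatter of two such steps. The long chains also stay clearly apart from the short ones, with an 11-fold lower number from compound 2 to compound 4 (1.04 log units; beyond the scatter) and a 6.3-fold lower number from compound 1 to compound 4 (0.80 log units; beyond the scatter), and the larger change keeps much the same size on both cores: the same change on two cores in this assay, a 9.2-fold lower number (0.96 log units; beyond the scatter) from compound 1 to compound 3 and an 11-fold lower number (1.04 log units; beyond the scatter) from compound 2 to compound 4, 1.2-fold (0.08 log units) apart, within the scatter of two such steps.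

The compounds shown leave open at which chain length between those of compound 2 and compound 3 the number falls, as a propyl, butyl or pentyl chain on the sulfur would show. Also open, from the compounds shown here alone, is whether a chain longer than that of compound 4, or an amine or a carboxylic acid at the end of the chain, would keep the number at this level in this assay.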